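The source may hold more compounds than are shown below. What is called first, only, known or untested is meant among the compounds shown, and "the series" means these compounds.

Three compounds have been measured in an assay on CHO cells for displacement of a labelled ligand from adenosine receptor A1 (Homo sapiens), tested at 10 uM; on this read-out lower numbers stand for less inhibition and higher numbers for more inhibition at the one concentration tested (going by the name of the read-out):

compound 1, `O=C(Nc1nn(-c2ccccc2)c(=O)c2ccccc12)c1ccccc1`, gives 44%;
compound 2, `COc1ccc(NC(=O)Nc2nn(-c3ccccc3)c(=O)c3ccccc23)cc1`, gives 4%;
compound 3, `O=C(Nc1nn(-c2ccccc2)c(=O)c2ccccc12)c1ccco1`, gives 23%.

Compound 3 stands second highest of the three, with compound 2 nearest below it and compound 1 furthest above it. Compound 4, `COc1ccccc1CNC(=O)Nc1nn(-c2ccccc2)c(=O)c2ccccc12`, has not yet been measured; it differs from compound 3 in one place: (2-methoxybenzyl)amino in place of furan-2-yl on a carbonyl carbon. Among the measured compounds shown here, two measured steps bear on this change. Replacing the group on the carbonyl carbon by an amino group gave a number 40 percentage points lower from compound 1 to compound 2 (beyond the scatter), while the reverse kind of exchange, from an amino group to furan-2-yl, gave a number 19 percentage points higher from compound 2 to compound 3 (beyond the scatter). For the measured compounds named here, compound 4 again carries an amino group on that carbonyl carbon, so a step downward in this assay beyond the scatter is expected, though compound 2 is the only measured compound of this type and the benzyl link in compound 4 has no measured counterpart. Compound 4 is therefore estimated at 10%, with a likely range from 0% to 30%, which would mean an expected step of a number 13 percentage points lower from compound 3 to compound 4 (beyond the scatter).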

Compound 4, a percentage reported as inhibition, at one concentration (the size of the read-out at that concentration, not a potency): 28%
Beside the measured number, compound 4's estimate is 18 percentage points below it, within the range that was stated.
By their numbers in this assay, from the lowest: compound 2; then compounds 3 and 4 (each within the scatter of the next); then compound 1.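

Putting (2-methoxybenzyl)amino in place of furan-2-yl leaves the number in this assay effectively unchanged, with a number 5 percentage points higher from compound 3 to compound 4 (within the scatter), yet the compound still falls short of the phenyl-bearing parent, with a number 16 percentage points lower from compound 1 to compound 4 (beyond the scatter). An amino group on this carbonyl carbon therefore does not by itself go with the very low number of compound 2: with a number 24 percentage points higher from compound 2 to compound 4 (beyond the scatter), what the amino nitrogen carries makes a difference beyond the scatter. No measurement at hand accounts for these differences.

The step between compound 2 and compound 4 swaps 4-methoxyphenyl for 2-methoxybenzyl, so the compounds shown cannot separate the effect of the methylene link from that of the place of the methoxy group. Going by these compounds, how an unsubstituted benzylamino group, a 4-methoxybenzylamino group or a longer chain such as 2-phenylethylamino would read here remains open.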